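The source may report more compounds than this note shows. Statements on the series, on what has been measured and on what is new or still open speak of the compounds shown alone.

Two compounds sharing the core of compound 1 `Cc1cnn(C(=O)N(C)CCN(C)Cc2ccc(OCc3ccccc3)cc2)c1` have so far been tested in an assay on membranes from brain for binding affinity to Monoglyceride lipase (Mus musculus), read by fluorescence, with stated times of 1 h and 30 min (a lower number here means a stronger inhibitor, a higher number a weaker inhibitor), and compound 1 gives 1200 nM in this assay. Compound 2 `Cc1cnn(C(=O)N(C)CCN(C)C(c2ccc(OCc3ccccc3)cc2)c2ccc(OCc3ccccc3)cc2)c1` is reported in this assay only as a limit, > 1000000 nM, not as a number. Compound 2 thus sits at the limit of > 1000000 nM in this assay, at which 1 of the 2 values shown sits, the weak end of what this assay can report. Compound 3 `CN(CCN(C)C(c1ccc(OCc2ccccc2)cc1)c1ccc(OCc2ccccc2)cc1)C(=O)n1cccn1` is next to be measured and differs from compound 2 in one place: hydrogen in place of methyl on an aromatic carbon. Going by the values given here, no measured pair shows what this change does, so the expectation rests on compound 2 alone. Such a small change is expected to shift the value little, so the step from a number no higher from compound 2 to compound 3 (the limit leaves the size open) is expected to be about none beyond the scatter. Compound 3 is therefore estimated at 1000000 nM, within 200000 nM to 5000000 nM.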

Compound 3, half-maximal inhibitory concentration: > 1000000 nM
Compound 3: only a limit was reported; the forecaster's own chance of this, stated with the estimate: 80%; the middle value lies on the limit itself.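

Compound 2 and compound 3 are both reported only as limits and not as numbers, so no step can be read between them, because both sit at the weak end: the limit of > 1000000 nM in this assay, at which 2 of the 3 values shown sit.

The compounds shown leave open whether replacing 4-methyl-1H-pyrazol-1-yl with 1H-pyrazol-1-yl changes inhibition at all.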